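Swapping methylsulfonyl for methoxycarbonyl on compound 2

This account rests on a few compounds, and the source may have more. Where it says the series, first, only, none or still open, it means among the compounds named here.

- compound 1 `CC1=CC(C)(C)Nc2c(C(=O)NC/C=C/S(C)(=O)=O)cccc21`: 27000 nM
- compound 2 `C[C@@H]1CC(C)(C)Nc2c(C(=O)NC/C=C/S(C)(=O)=O)cccc21`: > 25000 nM (a limit)
- compound 3 `C[C@@H]1CC(C)(C)Nc2c(C(=O)N[C@@H](C)/C=C/S(C)(=O)=O)cccc21`: > 25000 nM (a limit)

In an ADME assay on N2a cells (Mus musculus) for cytotoxicity (a higher number here means that more compound is tolerated, a lower number that less compound is tolerated), compound 2 gives > 25000 nM, which is a limit of the assay and not a number. Compound 3 also sits at a limit, so the limit of > 25000 nM in this assay, at which 2 of the 3 values shown sit, describes most of what is known so far.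

Compound 4 `COC(=O)/C=C/CNC(=O)c1cccc2c1NC(C)(C)C[C@H]2C` is compound 2 with a single exchange: methoxycarbonyl in place of methylsulfonyl on a double-bonded chain carbon bound to a double-bonded chain carbon. Going by the values given here, the one measured step, a step that the two limits leave unreadable from compound 2 to compound 3, puts methyl in place of hydrogen on a saturated chain carbon, not at the group exchanged here, and its size cannot be read. Among the compounds with values here, no measured step covers methoxycarbonyl in place of methylsulfonyl.

Within the data shown here, the best guide is compound 1 at 27000 nM, the only true number, so the expectation stays in that high region. The expected change, an at least 1.2-fold lower number from compound 2 to compound 4 (0.09 log units; that floor lies within the scatter), is an estimate and is small, if it can be read at all. For compound 4 the estimated value is 20000 nM, with an expected range of 8000 nM to 40000 nM.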

Compound 4, half-maximal cytotoxic concentration: > 25000 nM
Compound 4 was reported as a limit (the forecaster's own chance of this, stated with the estimate: 45%); at least 1.2-fold (0.09 log units) between middle value and limit.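

Compound 4, like compound 2 and compound 3, is reported only as a limit and not a number, so the steps linking them cannot be read: the limit of > 25000 nM in this assay, at which 3 of the 4 values shown sit.

Going by these compounds, whether methoxycarbonyl in place of methylsulfonyl changes how much compound the cells tolerate stays open.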